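A few compounds are considered here, and "the series" means these few. Any claim that something is new, unique, unknown or untested is made for them only; others in the source may bear on it.

Measured so far:
- compound 1, `CC(C)Oc1cc(Oc2cnc(C(=O)N(C)C)nc2)cc(-c2nccc(=O)[nH]2)c1`, gives 0.97 in a physicochemical assay for lipophilicity, using the shake flask method; a higher number here means a more lipophilic compound, a lower number a more polar compound
- compound 2, `CN(C)C(=O)c1ncc(Oc2cc(OC3CCOC3)cc(-c3nccc(=O)[nH]3)c2)cn1`, gives "not determined" (no result reported) in this assay, that is, no reported result

For the measured compounds named here, compound 1 is therefore the only compound with a number in this assay, and it stands alone: compound 2 gives nothing to set beside it, so no step between measured compounds can be read from these data. The value of compound 1 is the single fixed point from which anything further has to be judged.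

The compound still to be measured is compound 3, `Cc1cnc(-c2cc(Oc3cnc(C(=O)N(C)C)nc3)cc(OC(C)C)c2)[nH]c1=O`. Set against compound 1, the change is a single one: methyl in place of hydrogen on an aromatic carbon. Everything else in the two structures is the same, so whatever compound 3 shows in this assay can be read against compound 1 directly.

Going by the values given here, since no comparable step is available among the measured compounds, the expectation can only be stated as such. A small rise is expected, just beyond the usual scatter rather than a large jump: the step from compound 1 to compound 3 is estimated at a number 0.38 log units higher from compound 1 to compound 3 (beyond the scatter). For compound 3 itself, the expected result in this assay is 1.35, with a likely range from 1 to 1.7.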

Compound 3, distribution coefficient: 1.48
Compound 3: the middle estimate sits 0.13 log units below what was measured; the measured number falls inside the stated range.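

For the compounds shown here, until now, this assay offered one number and no step to read. Compound 3 supplies the first: placing methyl in position of a hydrogen on an aromatic carbon, two atoms from the ring nitrogen and para to a large group, gives a number 0.51 log units higher from compound 1 to compound 3 (beyond the scatter). The result shows that at this position a methyl of 1 heavy atom, with no ring, 0 hydrogen-bond donors, 0 hydrogen-bond acceptors and no net charge, is enough to carry the reading past the usual scatter, while everything else in the structure stays the same. Nothing measured here speaks to the cause of this step.

This one step leaves open whether a longer chain such as ethyl, or a different group such as an amine, a carboxylic acid or a fluorine atom, would move the reading at this position in the same direction, and whether methyl elsewhere on the shared core would do what it does here. Compound 2 has no reported result in this assay, so any step involving it cannot be read.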